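Benzyloxy ring substituents on the shared core: outlook for compound 3

This account rests on a few compounds, and the source may have more. Where it says the series, first, only, none or still open, it means among the compounds named here.

Measured so far:
compound 1, `Cc1ccc(NC(=S)NC(=O)c2ccc(OCc3ccccc3)cc2)cc1-c1nc2ccccc2[nH]1`, in a functional assay on MGC-803 cells (Homo sapiens) for inhibition, read by MTT assay, with a stated time of 48 h (a higher number here means a weaker inhibitor, a lower number a stronger inhibitor), gives 60700 nM
compound 2, `Cc1ccc(NC(=S)NC(=O)c2ccc(OCc3ccccc3Cl)cc2)cc1-c1nc2ccccc2[nH]1`, in this assay gives 45000 nM

Compound 2 and compound 1 stand within the scatter of each other: the step of a 1.3-fold lower number from compound 1 to compound 2 (0.13 log units; within the scatter) does not separate them, so nothing can be said about one being the stronger inhibitor. This single step is all that is known about changes on the benzyl ring of the shared core.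

Compound 3, `Cc1ccc(NC(=S)NC(=O)c2ccc(OCc3ccc(F)cc3)cc2)cc1-c1nc2ccccc2[nH]1`, differs from compound 2 by 4-fluorophenyl in place of 2-chlorophenyl on a saturated chain carbon bound to an oxygen on an aromatic ring. Among the compounds with values here, the only measured step that bears on this part of the molecule is the one from compound 1 to compound 2, where a chloro in place of hydrogen on an aromatic carbon gave a 1.3-fold lower number from compound 1 to compound 2 (0.13 log units; within the scatter), a change within the scatter. Swapping the halogen and its ring for a 4-fluorophenyl has no closer precedent here. The expectation for this assay is therefore no step beyond the scatter; for compound 3 the expected step is a 1.1-fold higher number from compound 2 to compound 3 (0.05 log units; within the scatter).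

Compound 3 is estimated in this assay at 50000 nM, with a range of 20000 nM to 125000 nM.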

Compound 3, half-maximal inhibitory concentration: 2810 nM
Beside the measured number, compound 3's estimate is 18-fold (1.25 log units) above it; the whole stated range lies above it.
By their numbers in this assay, from the lowest: compound 3; then compounds 2 and 1 (each within the scatter of the next).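

In this assay this position on the shared core proves able to move the number well beyond the scatter: 4-fluorophenyl in place of 2-chlorophenyl on a saturated chain carbon bound to an oxygen on an aromatic ring gives a 16-fold lower number from compound 2 to compound 3 (1.20 log units; beyond the scatter) and 4-fluorobenzyl in place of plain benzyl gives a 22-fold lower number from compound 1 to compound 3 (1.33 log units; beyond the scatter). The presence of a halogen on this ring is therefore not enough by itself: compound 2 with its 2-chlorobenzyl stays within the scatter of compound 1 with its plain benzyl, while compound 3 with its 4-fluorobenzyl stands apart from both. Nothing available here accounts for that gap.

Compound 2 and compound 3 differ in both the halogen and where it sits, so the compounds shown cannot tell which of the two carries the large step. A chloro or a methoxy group at the place the fluoro holds in 4-fluorophenyl, and a fluoro at the place the chloro holds in 2-chlorophenyl, would separate those two contributions.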